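Ring swap at the distal aryl of the sulfonamide series

The source may report more compounds than this note shows. Statements on the series, on what has been measured and on what is new or still open speak of the compounds shown alone.

Measured so far:
compound 1, `COc1ccc(NS(=O)(=O)c2ccc(-c3ccccn3)s2)cc1N1C[C@@H](C)N[C@@H](C)C1` — 0.9
compound 2, `COc1ccc(F)c(-c2ccc(S(=O)(=O)Nc3cc(N4C[C@@H](C)N[C@@H](C)C4)ccc3OC)cc2)c1` — 1.2

Two compounds have numbers in a functional assay for agonist activity at growth hormone secretagogue receptor type 1 (Homo sapiens), read by FLIPR; a higher number here means a larger maximal response, a lower number a smaller maximal response. Compound 1 gives 0.9. Compound 2 gives 1.2 and stands highest of the two; its nearest neighbour is compound 1, whose number is lower by an amount beyond the usual scatter. Going by the values given here, no pair differing in one place has been measured, so no step size is on record for this read-out.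

Compound 3, `COc1ccc(N2C[C@@H](C)N[C@@H](C)C2)cc1NS(=O)(=O)c1ccc(-c2cncnc2)cc1`, is not yet measured. Relative to compound 2 the change is pyrimidin-5-yl in place of 2-fluoro-5-methoxyphenyl on an aromatic carbon, at the place described: on an aromatic carbon of a six-membered aromatic ring of carbon only, para to a large group.

Both measured compounds reach a maximal response near that of the reference agonist, so the expected effect of the change is small: the step from compound 2 to compound 3 is estimated as a number 0.20 lower from compound 2 to compound 3 (beyond the scatter), downward but likely within the scatter. Compound 3 is expected to give 1 in this assay, in a range from 0.8 to 1.2.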

Compound 3, intrinsic activity: the largest response reached, as a fraction of the reference agonist's: 0.6
Beside the measured number, compound 3's estimate is 0.40 above it; the measured number lies below the stated range.
By their numbers in this assay, from the lowest: compound 3; then compound 1; then compound 2.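

In this assay this position, on an aromatic carbon of a six-membered aromatic ring of carbon only and para to a large group, does not tolerate every ring equally: the swap gives a large step, a number 0.60 lower from compound 2 to compound 3 (beyond the scatter), the first on record for this read-out. The maximal response therefore depends on what sits at this place, and the change behind the step takes out 2-fluoro-5-methoxyphenyl, a ring of carbon only with 9 heavy atoms, and puts in pyrimidin-5-yl, a ring with 2 hetero atoms and 6 heavy atoms. Nothing on hand bears on why the response falls with this swap.

The swap alters the ring atoms and the substituents at once, so the compounds shown do not separate the two, and an unsubstituted phenyl or a pyridin-3-yl at the same place would be needed to tell them apart. Also open, from the compounds shown here alone, is how a methoxy group or an amino group carried on the pyrimidin-5-yl ring would read in this assay.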